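A few compounds are considered here, and "the series" means these few. Any claim that something is new, unique, unknown or untested is made for them only; others in the source may bear on it.

Measured in a functional assay on CWR22R cells (Homo sapiens) for antiproliferative activity, read by CCK-8 assay, with a stated time of 6 days; a higher number here means a weaker inhibitor, a lower number a stronger inhibitor:
- compound 1 `C[C@@H](Cn1ccc(-c2ccc(C#N)c(Cl)c2)n1)NC(=O)c1ccccc1F`: "not determined" (no result reported)
- compound 2 `C[C@@H](Cn1ccc(-c2ccc(C#N)c(Cl)c2)n1)Nc1ccccc1`: > 30000 nM (a limit)
- compound 3 `C[C@@H](Cn1ccc(-c2ccc(C#N)c(Cl)c2)n1)Nc1ccccn1`: > 30000 nM (a limit)

Compound 3 has no numerical value in this assay, only the limit > 30000 nM. Compound 2 is also known only through a limit, and compound 1 has no reported result, so none of the three compounds gives a number to work from.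

The next compound is compound 4 `C[C@@H](Cn1ccc(-c2ccc(C#N)c(Cl)c2)n1)Nc1ccncc1`, which has the same atoms as compound 3, joined differently: pyridin-4-yl in place of pyridin-2-yl on an amine nitrogen. In words, this is pyridin-4-yl in place of pyridin-2-yl on an amine nitrogen.

Among the compounds with values here, the one measured step that bears on this change is a step that the two limits leave unreadable from compound 2 to compound 3. It involves a change on the same amine nitrogen, but it has no size that can be carried over. The only reference left is the limit of > 30000 nM in this assay, at which 2 of the 3 values shown sit, which includes compound 2 and compound 3. On that basis, no step beyond the scatter is expected in this assay, and no direction is favoured. The estimated step is a number no higher from compound 3 to compound 4 (the limit leaves the size open).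

Compound 4 is estimated at 30000 nM, with an expected range of 10000 nM to 60000 nM, and another report as a limit is the likeliest outcome.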

Compound 4, half-maximal inhibitory concentration: 11500 nM
The estimate for compound 4 lay 2.6-fold (0.42 log units) above the measured number; low and high end bracket the measured number.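

Changing pyridin-2-yl to pyridin-4-yl on the amine nitrogen is enough to give a measurable response in this assay, with an at least 2.6-fold lower number from compound 3 to compound 4 (0.41 log units; beyond the scatter), and compound 4, at 11500 nM, holds the only number among the compounds shown. Pyridin-4-yl in place of phenyl on the same nitrogen gives an at least 2.6-fold lower number from compound 2 to compound 4 (0.41 log units; beyond the scatter), while the step from phenyl to pyridin-2-yl cannot be read, so the gain is tied here to pyridin-4-yl and not to pyridine rings in general. Both readable steps are minimum sizes because compound 2 and compound 3 are each known only as a limit: the limit of > 30000 nM in this assay, at which 2 of the 4 values shown sit.

The true size of these steps and the reason for them remain open, and that line gives no cause for the change. Also open, going by these compounds, is whether pyridin-3-yl, pyrimidin-4-yl or a pyridin-4-yl ring carrying a methyl or an amino group on the same nitrogen would lower the number further in this assay.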